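The source may report more compounds than this note shows. Statements on the series, on what has been measured and on what is new or still open speak of the compounds shown alone.

In a functional assay on HeLa cells (Homo sapiens) for cytotoxicity, with a stated time of 3 days (a lower number here means a stronger inhibitor, a higher number a weaker inhibitor), three compounds sharing one core have been measured. Among the compounds with values here, compound 1 `Clc1ccc(-c2cc(-c3cccs3)nc(-c3cccs3)c2)o1` gives 55200 nM, and compound 2 `Clc1ccc(-c2cc(-c3ccsc3)nc(-c3cccs3)c2)o1` gives 43700 nM; the step of a 1.3-fold lower number from compound 1 to compound 2 (0.10 log units; within the scatter) is the only measured pair that differs in a single place, and it stays within the scatter. Compound 3 `Cc1ccsc1-c1cc(-c2ccco2)cc(-c2cccs2)n1` gives 17900 nM, the lowest of the three numbers, with compound 2 the nearest and compound 1 the furthest from it, both beyond the scatter. Compound 4 `Cc1ccsc1-c1cc(-c2ccco2)cc(-c2ccsc2)n1` has not yet been measured in this assay. Its difference from compound 3 is thiophen-3-yl in place of thiophen-2-yl on an aromatic carbon. Within the data shown here, the one measured step that bears on this change is a 1.3-fold lower number from compound 1 to compound 2 (0.10 log units; within the scatter), the same swap on the same carbon of the core, and it moved the number only within the scatter. The step of a 1.3-fold lower number from compound 3 to compound 4 (0.11 log units; within the scatter) is therefore expected to be small, with at most a slight move toward a lower number. Compound 4 is accordingly estimated at 14000 nM, within a range from 6000 nM to 40000 nM.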

Compound 4, half-maximal inhibitory concentration: 19200 nM
Compound 4: the middle estimate sits 1.4-fold (0.14 log units) below what was measured; measured number inside the range.
By their numbers in this assay, from the lowest: compounds 3 and 4 (each within the scatter of the next); then compounds 2 and 1 (each within the scatter of the next).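

Thiophen-3-yl in place of thiophen-2-yl, on the aromatic carbon next to the ring nitrogen, now has a reading on a second core in this assay, giving a 1.1-fold higher number from compound 3 to compound 4 (0.03 log units; within the scatter). What earlier rested on a single pair therefore holds for two, with the number staying within the scatter on both cores and the two steps agreeing with each other: the same change on two cores in this assay, a 1.3-fold lower number (0.10 log units; within the scatter) from compound 1 to compound 2 and a 1.1-fold higher number (0.03 log units; within the scatter) from compound 3 to compound 4, 1.4-fold (0.13 log units) apart, within the scatter of two such steps No direction can be read from these steps, and on these two cores the point of attachment of this thiophene does not register in the read-out.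

All the compounds shown keep a thiophene in this place, so it remains open how the number would respond to a different group there, such as a phenyl ring, a primary amine or a carboxylic acid. From the compounds shown here alone, it also remains open whether the same insensitivity extends to any core beyond these two.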